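Hydrazone aryl variation on a benzothiazole amide scaffold

The source may report more compounds than this note shows. Statements on the series, on what has been measured and on what is new or still open speak of the compounds shown alone.

Compound 1 `O=C(N/N=C/c1ccc(O)cc1)c1ccc(-c2nc3ccccc3s2)cc1` carries a 4-hydroxyphenyl on the carbon with a double bond to nitrogen. In an assay on isolated protein for inhibition of Maltase-glucoamylase (Homo sapiens), with a stated time of 15 min (on this read-out higher numbers stand for weaker inhibition and lower numbers for stronger inhibition), compound 1 gives 11300 nM. Of the three numbers in hand, that is the second highest: compound 2 `O=C(N/N=C/c1cccs1)c1ccc(-c2nc3ccccc3s2)cc1` gives 8480 nM, and the step of a 1.3-fold lower number from compound 1 to compound 2 (0.12 log units; within the scatter) lies within the scatter; compound 3 `COc1cc(/C=N/NC(=O)c2ccc(-c3nc4ccccc4s3)cc2)ccc1O` gives 53300 nM, and the step of a 4.7-fold higher number from compound 1 to compound 3 (0.67 log units; beyond the scatter) lies beyond it. The companion step a 6.3-fold higher number from compound 2 to compound 3 (0.80 log units; beyond the scatter) points the same way.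

Compound 4 `COc1ccc(/C=N/NC(=O)c2ccc(-c3nc4ccccc4s3)cc2)c(I)c1O` differs from compound 1 at the same place: 3-hydroxy-2-iodo-4-methoxyphenyl in place of 4-hydroxyphenyl on a carbon with a double bond to nitrogen. The step from compound 1 to compound 3 is the only measured one that shares a part of this change, the methoxy entering on an aromatic carbon, and it raised the number modestly. Among the measured compounds shown here, no measured step covers the iodine or the shifted hydroxy, so those parts of the change carry no information here. On this basis the number for compound 4 in this assay is expected to rise by about the size seen from compound 1 to compound 3, giving an expected step of a 3.5-fold higher number from compound 1 to compound 4 (0.55 log units; beyond the scatter). Compound 4 is therefore estimated at 40000 nM, with a range from 12000 nM to 130000 nM.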

Compound 4, half-maximal inhibitory concentration: 44800 nM
The estimate for compound 4 lay 1.1-fold (0.05 log units) below the measured number; the range from low to high includes it.
By their numbers in this assay, from the lowest: compounds 2 and 1 (each within the scatter of the next); then compounds 4 and 3 (each within the scatter of the next).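

In this assay, the 3-hydroxy-2-iodo-4-methoxyphenyl group of compound 4 reads with the 4-hydroxy-3-methoxyphenyl group of compound 3, with a 1.2-fold lower number from compound 3 to compound 4 (0.08 log units; within the scatter), while a 4.0-fold higher number from compound 1 to compound 4 (0.60 log units; beyond the scatter) and a 5.3-fold higher number from compound 2 to compound 4 (0.72 log units; beyond the scatter) place it clear of the other two compounds. At this position on the carbon with a double bond to nitrogen, both aryl groups carrying a methoxy therefore give higher numbers than 4-hydroxyphenyl and thiophen-2-yl, a split that holds for all four compounds with none against it, and exchanging one methoxy-bearing group for the other, with iodine entering, leaves no readable difference. Nothing on hand accounts for this split or for the lack of a difference between compound 3 and compound 4.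

Going by these compounds, the separate contributions of the iodine, the methoxy and the placing of the hydroxy remain open, since the change from compound 3 to compound 4 alters these together. Also open, on these data alone, is how this position would read with an amine, a carboxylic acid or a longer chain such as butyl on the aryl ring in place of these groups.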